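Chain extension in a sodium/hydrogen exchanger inhibitor series

A few compounds are considered here, and "the series" means these few. Any claim that something is new, unique, unknown or untested is made for them only; others in the source may bear on it.

Three compounds are measured in a functional assay for inhibition of sodium/hydrogen exchanger (Oryctolagus cuniculus); on this read-out lower numbers stand for stronger inhibition and higher numbers for weaker inhibition. Compound 1 `Cc1cc(C)c(S(C)(=O)=O)cc1C(=O)N=C(N)N` gives 11 nM, compound 2 `CCc1cc(C)c(C(=O)N=C(N)N)cc1S(C)(=O)=O` gives 4.8 nM, and compound 3 `CCSc1cc(C)c(C(=O)N=C(N)N)cc1S(C)(=O)=O` gives 5.9 nM. The change methyl in place of hydrogen on a saturated chain carbon bound to an aromatic carbon made a 2.3-fold lower number from compound 1 to compound 2 (0.36 log units; beyond the scatter). The change ethylsulfanyl in place of methyl on an aromatic carbon made a 1.9-fold lower number from compound 1 to compound 3 (0.27 log units; within the scatter), and between the two larger analogues there is a 1.2-fold higher number from compound 2 to compound 3 (0.09 log units; within the scatter), so compound 2 and compound 3 sit together.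

Compound 4 `CCCSc1cc(C)c(C(=O)N=C(N)N)cc1S(C)(=O)=O` is not yet measured. It differs from compound 3 by methyl in place of hydrogen on a saturated chain carbon, two bonds along the chain from a sulfur. Among the measured compounds shown here, this is the same kind of change as the one from compound 1 to compound 2, not the same change: the cores differ by ethylsulfanyl in place of methyl on an aromatic carbon, and the place differs, on a saturated chain carbon bound to an aromatic carbon in the earlier pair against on a saturated chain carbon, two bonds along the chain from a sulfur in the new one.

In this assay, the step from compound 3 to compound 4 is expected to be a 1.3-fold lower number from compound 3 to compound 4 (0.12 log units; within the scatter), set beside a 2.3-fold lower number from compound 1 to compound 2 (0.36 log units; beyond the scatter). This expectation rests on a single earlier step at a different place and on compound 3 already giving 5.9 nM, which leaves limited room. Compound 4 is estimated at 4.5 nM, with a likely range from 1.8 nM to 11 nM.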

Compound 4, half-maximal inhibitory concentration: 6.8 nM
Estimate against measurement, compound 4: 1.5-fold (0.18 log units) below; measured number inside the range.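

In this assay, methyl in place of hydrogen on a saturated chain carbon, two bonds along the chain from a sulfur, gives a 1.2-fold higher number from compound 3 to compound 4 (0.06 log units; within the scatter), and this step cannot be told apart from the earlier one of the same kind on the core of compound 1: the same change on two cores in this assay, a 2.3-fold lower number (0.36 log units; beyond the scatter) from compound 1 to compound 2 and a 1.2-fold higher number (0.06 log units; within the scatter) from compound 3 to compound 4, 2.6-fold (0.42 log units) apart, within the scatter of two such steps

Compound 4 also stays within the scatter of both other analogues, with a 1.4-fold higher number from compound 2 to compound 4 (0.15 log units; within the scatter) and a 1.6-fold lower number from compound 1 to compound 4 (0.21 log units; within the scatter), so it cannot be ranked against compound 1, compound 2 or compound 3. With one pair on each core, and the change at a different place in each, these data neither show that the step carries over from one core to the other at a fixed size nor show that it fails to carry over.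

The compounds shown leave open how a longer chain such as butylsulfanyl or a branched chain such as isopropylsulfanyl would read in this assay. They also leave open whether an amine in place of the sulfur would give a number in the same range.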